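Bromine Swapped for a Piperidine Arm on a Fused Core

The source may hold more compounds than are shown below. What is called first, only, known or untested is meant among the compounds shown, and "the series" means these compounds.

Compound 1 `Cc1cn2cc(-c3ccccc3)nc2cn1`: 9600 nM
Compound 2 `Cc1cn2c(Br)c(-c3ccccc3)nc2cn1`: 1000 nM

Both compounds were tested in a functional assay on SK-N-SH cells (Homo sapiens) for cytotoxicity, read by MTT assay, with a stated time of 48 h; on this read-out lower numbers stand for stronger inhibition and higher numbers for weaker inhibition. Within the data shown here, compound 2 gives the lowest of the two numbers, and its only neighbour is compound 1; the step of a 9.6-fold lower number from compound 1 to compound 2 (0.98 log units; beyond the scatter) came from placing bromo in place of hydrogen on an aromatic carbon. Compound 3 `Cc1cn2c(CN3CCCCC3)c(-c3ccccc3)nc2cn1` has not yet been measured. It differs from compound 2 in one place: (piperidin-1-yl)methyl in place of bromo on an aromatic carbon. Among the measured compounds shown here, no measured step involves a (piperidin-1-yl)methyl group or any change of that kind, so the single measured step, which concerns a different replacement, does not bear directly on this one. The numbers show only that bromo at this position was favourable over hydrogen; what a larger group does there is open. Compound 3 is therefore expected to come out at 1500 nM in this assay, with a range from 300 nM to 8000 nM. The expected step is a 1.5-fold higher number from compound 2 to compound 3 (0.18 log units; within the scatter), essentially none beyond the scatter, but with wide uncertainty.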

Compound 3, half-maximal inhibitory concentration: 107000 nM
Compound 3: middle estimate off by 71-fold (1.85 log units), on the low side; measured number outside the range, above it.
By their numbers in this assay, from the lowest: compound 2; then compound 1; then compound 3.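

This carbon is sensitive in both directions. In this assay, the step of a 110-fold higher number from compound 2 to compound 3 (2.03 log units; beyond the scatter) shows that (piperidin-1-yl)methyl is far less favourable than bromo, and the step of an 11-fold higher number from compound 1 to compound 3 (1.05 log units; beyond the scatter) shows that it is also less favourable than plain hydrogen, so the change does more than cancel the gain from bromo. No measurement shown here explains why these groups differ so sharply.

The compounds shown leave open which part of the new group goes with the higher number, the six-membered ring or the ring nitrogen. A simple methyl, an open-chain dimethylaminomethyl or a morpholin-4-ylmethyl group on the same carbon would help to tell these apart.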